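Replacing benzyl with tert-butyl in compound 3

The source may hold more compounds than are shown below. What is called first, only, known or untested is meant among the compounds shown, and "the series" means these compounds.

Compound 1 `COc1ccc(-n2cc(/C=[N+](\[O-])Cc3ccccc3)nn2)cc1`: 17300 nM
Compound 2 `CCCCCCCCn1cc(/C=[N+](\[O-])Cc2ccccc2)nn1`: 13100 nM
Compound 3 `CCCCCCCCCCn1cc(/C=[N+](\[O-])Cc2ccccc2)nn1`: 15600 nM

In a functional assay on THP-1 cells (Homo sapiens) for inhibition, read by ELISA, with stated times of 2 h and 48 h (a higher number here means a weaker inhibitor, a lower number a stronger inhibitor), compound 3 sits within the usual scatter of both compound 1 and compound 2. Compound 4 `CCCCCCCCCCn1cc(/C=[N+](\[O-])C(C)(C)C)nn1` carries one change, on a double-bonded nitrogen: tert-butyl in place of benzyl on a double-bonded nitrogen. Among the measured compounds shown here, the only measured step between two compounds, a 1.2-fold higher number from compound 2 to compound 3 (0.08 log units; within the scatter), lies within the scatter, but it concerns the saturated chain and not this nitrogen. For the measured compounds named here, no measured pair shows what a change of group on that nitrogen does, so the guidance is indirect and the range must stay wide. The expected step is a 1.0-fold higher number from compound 3 to compound 4 (0.01 log units; within the scatter), which means no change beyond the scatter is expected in this assay. Compound 4 is estimated at 16000 nM, with an expected range of 6000 nM to 40000 nM.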

Compound 4, half-maximal inhibitory concentration: 20000 nM
Beside the measured number, compound 4's estimate is 1.3-fold (0.10 log units) below it, within the range that was stated.
By their numbers in this assay, from the lowest: compounds 2, 3, 1 and 4 (each within the scatter of the next).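

Among the compounds shown here, this is the first measured change of the group on the double-bonded nitrogen. In this assay putting tert-butyl in place of benzyl gives a 1.3-fold higher number from compound 3 to compound 4 (0.11 log units; within the scatter) and so, at this position, a group with no ring and four heavy atoms reads the same as a benzyl ring with seven, within the scatter. Nothing measured here offers an explanation for this result. Still open, on these data alone, is whether any group on this nitrogen moves the number beyond the scatter. A carboxylic acid, an amine or a longer chain there could test that.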